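Removing the amino group from compound 2

A few compounds are considered here, and "the series" means these few. Any claim that something is new, unique, unknown or untested is made for them only; others in the source may bear on it.

In a functional assay on HCT-116 cells (Homo sapiens) for inhibition, read by MTT assay, with a stated time of 48 h (a lower number here means a stronger inhibitor, a higher number a weaker inhibitor), compound 2 (`C/C=C/C(=O)N(Cc1ccc(OC)c(N)c1)c1cc(OC)c(OC)c(OC)c1`) gives 300 nM as its half-maximal inhibitory concentration. Compound 3 (`COc1ccc(CN(C(=O)CN=[N+]=[N-])c2cc(OC)c(OC)c(OC)c2)cc1O`) gives 410 nM in this assay and sits within the scatter of compound 2, so the two stand level on these numbers. Compound 1 (`COc1cc(NCc2ccc(Cl)cc2)cc(OC)c1OC`) reports > 80000 nM in this assay and this is a limit of the assay, not a number.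

The next compound to be measured is compound 4 (`C/C=C/C(=O)N(Cc1ccc(OC)cc1)c1cc(OC)c(OC)c(OC)c1`). It differs from compound 2 in one place, with hydrogen in place of amino on an aromatic carbon ortho to a methoxy group and meta to a large group. The 3-amino-4-methoxyphenyl of compound 2 thereby becomes 4-methoxyphenyl, while the rest of the structure stays the same.

No measured pair among these compounds isolates this change. The expectation therefore starts from compound 2 at 300 nM and remains a judgement. A step beyond the scatter toward a weaker inhibitor is expected in this assay although its size is uncertain. The estimated change is a 10-fold higher number from compound 2 to compound 4 (1.00 log units; beyond the scatter) as a move to a higher number. For compound 4 the expected value is 3000 nM with an estimated range from 600 nM to 15000 nM in the measurement still to come.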

Compound 4, half-maximal inhibitory concentration: 500 nM
The estimate for compound 4 lay 6.0-fold (0.78 log units) above the measured number, and the stated range ends above it.
By their numbers in this assay, from the lowest: compounds 2, 3 and 4 (each within the scatter of the next). At a limit, above all of these: compound 1.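

In this assay, exchanging the amino group for hydrogen turns the 3-amino-4-methoxyphenyl into 4-methoxyphenyl and gives a 1.7-fold higher number from compound 2 to compound 4 (0.22 log units; within the scatter), a step that lies within the scatter. Among these compounds, this is the first measured step at this aromatic carbon, ortho to a methoxy group, since no earlier pair isolated the change, and it shows that compound 4 stands level with compound 2 in this assay without the amino group. Nothing shown here accounts for this result.

The compounds shown leave open whether another group on this same aromatic carbon, such as a fluorine, a dimethylamino group or a carboxylic acid, would also stand level with compound 2 and compound 4 or would move the number beyond the scatter. Among the compounds shown here, they also leave open whether the exchange of amino for hydrogen would read the same way on an amide with a longer chain in place of the one that compound 2 and compound 4 share.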